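This account rests on a few compounds, and the source may have more. Where it says the series, first, only, none or still open, it means among the compounds named here.

Going by the values given here, compound 2 `Cc1ccc(-c2cnc(N(CCCOc3ccccc3)Cc3ccc(C(=O)NO)cc3)s2)cc1` gives 4140 nM in a functional assay on HCT-116 cells (Homo sapiens) for antiproliferative activity, read by MTT assay, with a stated time of 48 h (a higher number here means a weaker inhibitor of growth, a lower number a stronger inhibitor of growth), the highest of the two numbers so far; compound 1 `Cc1ccc(-c2cnc(N(CCCCOc3ccccc3)Cc3ccc(C(=O)NO)cc3)s2)cc1` gives 680 nM, and a 6.1-fold higher number from compound 1 to compound 2 (0.78 log units; beyond the scatter) is the only step measured. Compound 3 `CCCCCCCCN(Cc1ccc(C(=O)NO)cc1)c1ncc(-c2ccc(C)cc2)s1` carries pentyl in place of phenoxy on a saturated chain carbon, three bonds along the chain from a nitrogen on an aromatic ring. Among the compounds with values here, no measured step removes the aromatic ring or the oxygen from this chain; the one step on record shows only that the length of the chain matters, and it does not settle the direction here. The change is therefore expected to read a 2.1-fold lower number from compound 2 to compound 3 (0.32 log units; beyond the scatter), modest and not certain to pass the scatter. Compound 3 is estimated at 2000 nM, with a range from 500 nM to 8000 nM.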

Compound 3, concentration for 50% growth inhibition: 6500 nM
Compound 3: middle estimate off by 3.3-fold (0.51 log units), on the low side, within the range that was stated.
By their numbers in this assay, from the lowest: compound 1; then compounds 2 and 3 (each within the scatter of the next).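

In this assay, octyl in place of 3-phenoxypropyl gives a 1.6-fold higher number from compound 2 to compound 3 (0.20 log units; within the scatter), so at this position the phenoxy end can be exchanged for an all-carbon chain without a readable change. Butyl in place of phenoxy, four bonds along the chain from a nitrogen on an aromatic ring, gives a 9.6-fold higher number from compound 1 to compound 3 (0.98 log units; beyond the scatter), so the phenoxy end counts on the chain of compound 1 but not readably on that of compound 2. On these data alone, whether an amine or a carboxylic acid at the chain end, or a longer chain ending in phenoxy, would read lower than compound 1 stays open. No measurement on hand accounts for this difference between the two chains.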